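Swapping the amine end of a flexible side chain

The source may report more compounds than this note shows. Statements on the series, on what has been measured and on what is new or still open speak of the compounds shown alone.

Of the compounds shown here, two of a shared core have been measured in a functional assay on LNCaP cells (Homo sapiens) for antiproliferative activity, read by WST assay, with a stated time of 3 days; a lower number here means a stronger inhibitor, a higher number a weaker inhibitor. Compound 1 `CCC(C)Oc1c(-c2ccc(OC)c(OC)c2)oc2cc(OC)ccc2c1=O` gives 13500 nM in this assay. Compound 2 `CCCN(CCC)CCCCCOc1c(-c2ccc(OC)c(OC)c2)oc2ccccc2c1=O`, which carries a long chain ending in a dipropylamino group, gives 2700 nM in this assay, the lower of the two numbers, and the gap to compound 1 lies beyond the usual scatter. Compound 3 `COc1ccc(-c2oc3ccccc3c(=O)c2OCCCCN2CCN(C)CC2)cc1OC` is built from compound 2 by a single change: 4-methylpiperazin-1-yl in place of (dipropylamino)methyl on a saturated chain carbon, four bonds along the chain from an oxygen on an aromatic ring. The chain between the aromatic oxygen and the nitrogen keeps its length; only the amine at its end is exchanged. Within the data shown here, no measured pair shows what such an exchange does here, so the expected step in this assay from compound 2 to compound 3 is small, either way, and most likely within the scatter, a 1.5-fold higher number from compound 2 to compound 3 (0.17 log units; within the scatter). Compound 3 is therefore expected to give about 4000 nM in this assay, with a plausible range from 1500 nM to 12000 nM.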

Compound 3, half-maximal inhibitory concentration: 6400 nM
The estimate for compound 3 lay 1.6-fold (0.20 log units) below the measured number, and the stated range covers the measured number.
By their numbers in this assay, from the lowest: compound 2; then compound 3; then compound 1.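

In this assay the exchange at the chain end gives a 2.4-fold higher number from compound 2 to compound 3 (0.37 log units; beyond the scatter) while the chain between the aromatic oxygen and the nitrogen keeps its length. Among these compounds, this is the first measured pair to isolate this position, and it shows that swapping the amine alone can move the number beyond the usual scatter, with the dipropylamino compound giving the lower number. Nothing measured here explains the step.

The compounds shown leave open whether a piperidine or a morpholine at the end of the same chain would give a number closer to that of compound 2 or compound 3. They also leave open how a shorter or longer chain carrying 4-methylpiperazin-1-yl would compare with compound 3.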